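From a carbamoyl arm to a nitrobenzyl arm

The compounds below may be only part of what the source reports. "The series", "measured", "known", "first", "only" and "open" are said of these compounds alone.

Compound 3, `NC(=O)Cn1c(=O)n(C2OC(CO)[C@@H](O)[C@H]2O)c2nc(N)nc(O)c21`, stands at the top of the three measured compounds: in a functional assay on the whole organism with Mus musculus as the target (on this read-out higher numbers stand for larger maximal responses and lower numbers for smaller maximal responses), compound 3 gives 72%. Compound 1, `CCOC(=O)Cn1c(=O)n(C2OC(CO)[C@@H](O)[C@H]2O)c2nc(N)nc(O)c21`, gives 58% in this assay, and compound 2, `CCCCCCCCCCn1c(=O)n(C2OC(CO)[C@@H](O)[C@H]2O)c2nc(N)nc(O)c21`, which carries a nonyl chain, gives 0%. The two steps onto compound 3 are a number 14 percentage points higher from compound 1 to compound 3 (beyond the scatter) and a number 72 percentage points higher from compound 2 to compound 3 (beyond the scatter).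

Compound 4, `Nc1nc(O)c2c(n1)n(C1OC(CO)[C@@H](O)[C@H]1O)c(=O)n2Cc1ccc([N+](=O)[O-])cc1`, differs from compound 3 in one place: 4-nitrophenyl in place of carbamoyl on a saturated chain carbon bound to an aromatic nitrogen. The step that bears most on this change is the one in which carbamoyl replaced the nonyl chain, a number 72 percentage points higher from compound 2 to compound 3 (beyond the scatter), a large step; the step in which carbamoyl replaced ethoxycarbonyl, a number 14 percentage points higher from compound 1 to compound 3 (beyond the scatter), was modest. Among the compounds with values here, in both, the carbamoyl compound reached the larger response, so a move away from carbamoyl is expected to lower the response, probably by a large amount, though 4-nitrophenyl has no measured counterpart here. Compound 4 is expected to give about 30%, within a range of 5% to 60%. The expected step is a number 42 percentage points lower from compound 3 to compound 4 (beyond the scatter).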

Compound 4, largest response reached (reported as maximal response), in percent of the reference or control that the assay uses: 16%
Compound 4: the middle estimate sits 14 percentage points above what was measured, within the range that was stated.
By their numbers in this assay, from the lowest: compound 2; then compound 4; then compound 1; then compound 3.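

Replacing carbamoyl at this position, a saturated chain carbon bound to an aromatic nitrogen, with 4-nitrophenyl gives a number a number 56 percentage points lower from compound 3 to compound 4 (beyond the scatter), and replacing ethoxycarbonyl with it gives a number a number 42 percentage points lower from compound 1 to compound 4 (beyond the scatter), so an aromatic ring here does not match either carbonyl arm. The ring arm still keeps some response where the nonyl chain keeps none, with a number 16 percentage points higher from compound 2 to compound 4 (beyond the scatter), which places it in a new middle ground: among these four arms, the two with a carbonyl group reach the largest responses. Nothing in the available data explains this order.

Going by these compounds, how much of the drop belongs to the ring and how much to the nitro group stays open, and a plain benzyl arm would separate the two. On these data alone, whether a carboxylic acid or an amine on the same chain carbon could match carbamoyl also remains open.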